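Removing a Methoxy Group: Effect on Cell Growth Inhibition

This account rests on a few compounds, and the source may have more. Where it says the series, first, only, none or still open, it means among the compounds named here.

Of the compounds shown here, three sharing one core have been tested in a functional assay on HeLa cells (Homo sapiens) for antiproliferative activity, read by MTT assay, with a stated time of 72 h; a lower number here means a stronger inhibitor, a higher number a weaker inhibitor. Compound 3 `COc1ccc2occ(CSC(=S)N3CCCCC3)c(=O)c2c1` is the only one to give an actual number: in this assay compound 3 gives 3500 nM. Compound 1 `Cc1ccc2c(=O)c(CSC(=S)N3CCCCC3)coc2c1` reaches only a limit of the assay, > 25000 nM, not a number. Compound 2 `CC(C)N(C(=S)SCc1coc2ccccc2c1=O)C(C)C` likewise reaches only a limit, > 30000 nM. Compound 4 `O=c1c(CSC(=S)N2CCCCC2)coc2ccccc12` awaits measurement and differs from compound 3 in one place: hydrogen in place of methoxy on an aromatic carbon. Going by the values given here, no measured pair shows the size of such a step. Compound 4 is expected to be weaker, around 15000 nM, with a range from 4000 nM to 40000 nM, partly because compound 2, which also bears no group on that ring, gave only > 30000 nM. The expected step is a 4.3-fold higher number from compound 3 to compound 4 (0.63 log units; beyond the scatter).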

Compound 4, half-maximal inhibitory concentration: 2300 nM
For compound 4 the middle estimate is 6.5-fold (0.81 log units) above the measured one; the measured number lies below the stated range.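

Hydrogen in place of methoxy gives a 1.5-fold lower number from compound 3 to compound 4 (0.18 log units; within the scatter), so in this assay the methoxy group on this aromatic carbon is not needed for activity. The other two changes do matter: piperidin-1-yl in place of diisopropylamino gives an at least 13-fold lower number from compound 2 to compound 4 (1.11 log units; beyond the scatter), and hydrogen in place of methyl gives an at least 10-fold lower number from compound 1 to compound 4 (1.03 log units; beyond the scatter). Both of these steps start from a limit of the assay rather than a number, so they give only a minimum size.

Going by these compounds, whether an amine or a carboxylic acid on this carbon would shift the number remains open. So does the effect of a longer chain, such as propoxy, in place of methoxy.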